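The source may report more compounds than this note shows. Statements on the series, on what has been measured and on what is new or still open speak of the compounds shown alone.

Measured compounds:
- compound 1 `COc1ccc(-c2cc(-c3ccc(S(N)(=O)=O)cc3)cnc2N)cn1`: 12.5 ug/mL
- compound 2 `COc1ccc(-c2cc(-c3ccc(S(C)(=O)=O)cc3C(F)(F)F)cnc2N)cn1`: 12.5 ug/mL
- compound 3 `COc1ccc(-c2cnc(N)c(-c3ccc(OC)nc3)c2)cn1`: 25 ug/mL

Of the compounds shown here, three sharing a common core have been read in a physicochemical assay for solubility, read by nephelometry, in phosphate buffer, measured as kinetic solubility, at pH 6.5; a lower number here means a less soluble compound, a higher number a more soluble compound. Compound 1 gives 12.5 ug/mL, and compound 2 gives 12.5 ug/mL, the two standing level at the digits recorded. Compound 3 gives 25 ug/mL, the highest of the three numbers, yet its gap to compound 1 still lies within the scatter of this assay, so the three values are best read as one cluster rather than as an ordered series. Compound 1 thus sits at the low end of a narrow band.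

The step to compound 4 `COc1ccc(-c2cc(-c3ccc(-n4cncn4)cc3)cnc2N)cn1` is a single exchange: 1H-1,2,4-triazol-1-yl in place of sulfamoyl on an aromatic carbon, on an aromatic carbon of a six-membered aromatic ring of carbon only. Within the data shown here, no measured pair shows this exchange, so its effect on solubility is unknown from these data. Among the measured compounds shown here, compound 1 and compound 2 show that a change at this ring, from sulfamoyl to a methylsulfonyl group with a trifluoromethyl neighbour, left the number unmoved, which is the only guidance available. On that basis the step from compound 1 to compound 4 is expected to be no change at the digits printed from compound 1 to compound 4 (within the scatter), that is, none beyond the scatter. Compound 4 is therefore estimated at 12.5 ug/mL, with a range from 5 ug/mL to 30 ug/mL.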

Compound 4, solubility: 6.3 ug/mL
Estimate against measurement, compound 4: 2.0-fold (0.30 log units) above; the measured number falls inside the stated range.
By their numbers in this assay, from the lowest: compounds 4, 1, 2 and 3 (each within the scatter of the next, the first and the last beyond it).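

In this assay, among these compounds, the exchange of sulfamoyl for 1H-1,2,4-triazol-1-yl on an aromatic carbon, para to a large group, gives a 2.0-fold lower number from compound 1 to compound 4 (0.30 log units; within the scatter), the first reading at this position of a single exchange with nothing else altered. The position thus accepts a five-membered aromatic ring with 3 hetero atoms and 0 hydrogen-bond donors in place of sulfamoyl, with 1 hydrogen-bond donor, without a step beyond the scatter. Nothing at hand bears on what lies behind this reading.

The compounds shown leave open whether any group at this position would give a step beyond the scatter, for instance a carboxylic acid or an aliphatic amine such as morpholine. They also leave open whether the same exchange would read alike on a different core.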